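The source may report more compounds than this note shows. Statements on the series, on what has been measured and on what is new or still open speak of the compounds shown alone.

Measured in a functional assay on BGC-823 cells (Homo sapiens) for inhibition, read by MTT assay, with a stated time of 72 h; on this read-out lower numbers stand for stronger inhibition and higher numbers for weaker inhibition:
- Compound 1 `Cc1cc(N2CC[C@@H](C)[C@@H](N(C)c3ncnc4[nH]ccc34)C2)n2ncnc2n1`: 67400 nM
- Compound 2 `C[C@@H]1CCN(c2cc(-c3ccccc3)nc3ncnn23)C[C@@H]1N(C)c1ncnc2[nH]ccc12`: > 100000 nM, a limit of the assay
- Compound 3 `Cc1nc2nc(SCc3ccc(Cl)cc3)nn2c(N2CC[C@@H](C)[C@@H](N(C)c3ncnc4[nH]ccc34)C2)c1C`: > 100000 nM, a limit of the assay

Going by the values given here, compound 1 holds the only actual number here, since the other two entries are limits. Compound 4 `Cc1cc(N2CC[C@@H](C)[C@@H](N(C)c3ncnc4[nH]ccc34)C2)n2nc(SCc3ccc(F)cc3)nc2n1`, not yet measured, differs from compound 1 by (4-fluorobenzyl)sulfanyl in place of hydrogen on an aromatic carbon. Among the compounds with values here, the one measured step, phenyl in place of methyl on an aromatic carbon, is an at least 1.4-fold higher number from compound 1 to compound 2 (0.17 log units; that floor lies within the scatter). It changes a different place, and the series otherwise crowds at the limit of > 100000 nM in this assay, at which 2 of the 3 values shown sit. No step beyond the scatter is therefore expected in this assay, and the reading may again be only a limit. The estimated step is a 1.0-fold higher number from compound 1 to compound 4 (0.02 log units; within the scatter). The expected value for compound 4 is 70000 nM, within an estimated range from 25000 nM to 150000 nM.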

Compound 4, half-maximal inhibitory concentration: 44300 nM
Compound 4: middle estimate off by 1.6-fold (0.20 log units), on the high side, and the stated range covers the measured number.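

At the aromatic carbon between two ring nitrogen atoms, which carries only hydrogen in compound 1, a (4-fluorobenzyl)sulfanyl group gives a 1.5-fold lower number from compound 1 to compound 4 (0.18 log units; within the scatter). The position therefore takes this group with no step beyond the scatter, and compound 4 keeps a real number in this assay. Compound 2 and compound 3, by contrast, stand at a limit of the assay, not a number: the limit of > 100000 nM in this assay, at which 2 of the 4 values shown sit.

As far as these compounds go, whether an amine, a carboxylic acid or a longer alkyl chain at this carbon would give a step beyond the scatter remains open. So does the part played by the fluorine on the benzyl ring.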